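The source may report more compounds than this note shows. Statements on the series, on what has been measured and on what is new or still open speak of the compounds shown alone.

Measured compounds in a functional assay on HT-1080 cells (Homo sapiens) for cytotoxicity; on this read-out lower numbers stand for an effect already at smaller amounts and higher numbers for an effect only at larger amounts of compound:

- compound 1 `CCC[C@@H](OC(C)=O)C1=C(Br)C(=C(Br)Br)OC1=O`: "not determined" (no result reported)
- compound 2 `CCCCC1=C(Br)/C(=C/Br)OC1=O`: 2.2 ug/mL
- compound 3 `CCC[C@@H](O)C1=C(Br)/C(=C/I)OC1=O`: "not determined" (no result reported)

Compound 1 stands without a number in this assay; compound 3 likewise has none. Only compound 2 gives a result, 2.2 ug/mL in this assay.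

Compound 4 `CCCCC1=C(Br)C(=C(Br)Br)OC1=O` is not yet measured. It differs from compound 1 by hydrogen in place of acetoxy on a saturated chain carbon bound to a double-bonded ring carbon and a saturated chain carbon. Within the data shown here, no step between measured compounds is known, so no size can be taken from the data. Since compound 2 also carries no acetoxy and gives 2.2 ug/mL, compound 4 is expected to land close to that value, with any difference from compound 2 most likely within the usual scatter.

Compound 4 is estimated at 2.5 ug/mL in this assay, within a range from 0.8 ug/mL to 8 ug/mL.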

Compound 4, concentration for half-maximal effect: > 20 ug/mL
Compound 4: a limit, no number; the forecaster's own chance of this, stated with the estimate: 10%; at least 8.0-fold (0.90 log units) between middle value and limit.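

In this assay compound 4 gives > 20 ug/mL, a limit and not a number. Among these compounds, compound 1 has no single number, so no step between compound 1 and compound 4 can be read. The compounds shown leave open what exchanging acetoxy for hydrogen does to this read-out.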